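Swapping Fluoro for Bromo on the Sulfonyl Ring

The source may hold more compounds than are shown below. What is called first, only, known or untested is meant among the compounds shown, and "the series" means these compounds.

Compound 1 `CC(O)(C(=O)Nc1ccc(S(=O)(=O)c2ccccc2)c(F)c1)C(F)(F)F`: 1800 nM
Compound 2 `CC(O)(C(=O)Nc1ccc(S(=O)(=O)c2ccc(F)cc2)cc1)C(F)(F)F`: 8600 nM
Compound 3 `CC(O)(C(=O)Nc1ccc(S(=O)(=O)c2ccccc2)c(O)c1)C(F)(F)F`: 430 nM

These values come from a functional assay (Cavia porcellus) with sulfonylurea receptors; K-ATP channels (Homo sapiens) as the target; a lower number here means a stronger inhibitor, a higher number a weaker inhibitor. Compound 2 gives the highest number of the three and is thus the weakest inhibitor here, with compound 1 the nearest to it and compound 3 the furthest away. Compound 4 `CC(O)(C(=O)Nc1ccc(S(=O)(=O)c2ccc(Br)cc2)cc1)C(F)(F)F` differs from compound 2 by bromo in place of fluoro on an aromatic carbon. Within the data shown here, the single measured step, a 4.2-fold lower number from compound 1 to compound 3 (0.62 log units; beyond the scatter), concerns a different ring and a different pair of groups, so no measured step speaks directly to exchanging one halogen for another at this place. The expectation for compound 4 is therefore a step from compound 2 that stays within the usual scatter, a 1.7-fold lower number from compound 2 to compound 4 (0.24 log units; within the scatter). Compound 4 is estimated at 5000 nM, between 1500 nM and 15000 nM.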

Compound 4, half-maximal inhibitory concentration: > 30000 nM
Compound 4 gave a limit, no number; the forecaster's own chance of this, stated with the estimate: 5%; middle value at least 6.0-fold (0.77 log units) from the limit.
By their numbers in this assay, from the lowest: compound 3; then compound 1; then compound 2. At a limit, above all of these: compound 4.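

Exchanging 4-fluorophenyl for 4-bromophenyl is not a neutral swap between two halogens: in this assay it gives an at least 3.4-fold higher number from compound 2 to compound 4 (0.54 log units; beyond the scatter). A change of one atom at this place is therefore enough to weaken inhibition beyond the scatter. Compound 4 gives a limit and not a number, so the full size of this step stays unknown: the limit of > 30000 nM in this assay, at which 1 of the 4 values shown sits.

The compounds shown leave open how chloro, an amine or a carboxylic acid would read at this place. They also leave open whether bromo here would cost as much on the core of compound 3.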